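Swapping one group on compound 1

The source may hold more compounds than are shown below. What is called first, only, known or untested is meant among the compounds shown, and "the series" means these compounds.

Compound 1 `O=C(Nc1ccc(Cl)cc1)c1c(NC(=O)C(F)(F)F)sc2c1CCCCC2`: > 50000 nM
Compound 2 `COc1ccc(NC(=O)c2ccsc2NC(=O)C(F)(F)F)cc1`: > 50000 nM
Compound 3 `COc1ccc(NC(=O)c2c(NC(=O)C(F)(F)F)sc3c2CCCC3)cc1`: > 50000 nM

These three compounds were tested in an ADME assay on THP-1 cells (Homo sapiens) for cytotoxicity; a lower number here means that less compound is tolerated, a higher number that more compound is tolerated. Compound 1 gives > 50000 nM, which is a limit of the assay and not a number. The whole set looks the same, with the limit of > 50000 nM in this assay, at which 3 of the 3 values shown sit.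

Compound 4 `COc1ccccc1NC(=O)c1c(NC(=O)C(F)(F)F)sc2c1CCCCC2` keeps the core of compound 1 but carries 2-methoxyphenyl in place of 4-chlorophenyl on an amide-type nitrogen. Among the measured compounds shown here, no measured pair shows this change alone, so no step beyond the scatter is expected in this assay. The expected size of a number no higher from compound 1 to compound 4 (the limit leaves the size open) is within the scatter. For compound 4 the estimated value is 50000 nM, with an expected range from 25000 nM to 100000 nM.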

Compound 4, half-maximal cytotoxic concentration: > 50000 nM
Compound 4: a limit, no number; the forecaster's own chance of this, stated with the estimate: 80%; the middle value lies on the limit itself.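

No step can be read between compound 1 and compound 4, because both values are limits of the assay and not numbers: the limit of > 50000 nM in this assay, at which 4 of the 4 values shown sit.

The compounds shown leave open where any of them would give a measurable value in this assay, and so whether 2-methoxyphenyl in place of 4-chlorophenyl makes any difference there.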